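The source may report more compounds than this note shows. Statements on the series, on what has been measured and on what is new or still open speak of the compounds shown alone.

Measured in a functional assay on HEL cells (Homo sapiens) for cytotoxicity; on this read-out lower numbers stand for higher toxicity in this test and higher numbers for lower toxicity in this test:

compound 1 `CCCCCCCCC#Cc1cc2cn([C@@H]3O[C@H](CO)[C@@H](O)[C@@H]3O)c(=O)nc2o1` — 49000 nM
compound 2 `CCCCCCCCCCC#Cc1cc2cn([C@@H]3O[C@H](CO)[C@@H](O)[C@@H]3O)c(=O)nc2o1` — 46000 nM
compound 3 `CCCCCCC#Cc1cc2cn([C@H]3C[C@H](O)[C@@H](CO)O3)c(=O)nc2o1` — >= 97000 nM

Compound 1 holds the highest of the two numbers in this assay, but compound 2 sits within the scatter of it: a 1.1-fold lower number from compound 1 to compound 2 (0.03 log units; within the scatter). The entry for compound 3 is a limit of the assay rather than a number, (the limit of >= 97000 nM in this assay, at which 1 of the 3 values shown sits).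

Compound 4 `CCCCC#Cc1cc2cn([C@@H]3O[C@H](CO)[C@@H](O)[C@@H]3O)c(=O)nc2o1` differs from compound 1 as follows: hydrogen in place of butyl on a saturated chain carbon, four bonds along the chain from a triple-bonded carbon. Among the measured compounds shown here, the only measured step is the one from compound 1 to compound 2, which lengthens the chain and stays within the scatter. For the measured compounds named here, compound 3 carries a shorter chain on a different sugar and reaches only the limit, so no step toward compound 4 can be computed from it. On that thin footing, shortening the chain in compound 4 is expected to leave the number unchanged or to raise it; the expected step is a 1.6-fold higher number from compound 1 to compound 4 (0.21 log units; within the scatter). Compound 4 is therefore estimated at 80000 nM, between 35000 nM and 150000 nM, with a real chance that this assay returns only a limit.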

Compound 4, minimum cytotoxic concentration: > 144000 nM
Compound 4: a limit, no number (the forecaster's own chance of this, stated with the estimate: 45%); middle value at least 1.8-fold (0.25 log units) away from the limit.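

In this assay compound 4 gives a limit, not a number: the limit of > 144000 nM in this assay, at which 1 of the 4 values shown sits.

Even so, hydrogen in place of butyl, four bonds along the chain from a triple-bonded carbon, produces changes beyond the scatter: an at least 2.9-fold higher number from compound 1 to compound 4 (0.46 log units; beyond the scatter) and an at least 3.1-fold higher number from compound 2 to compound 4 (0.49 log units; beyond the scatter). The step between the two longer chains stays within the scatter, a 1.1-fold lower number from compound 1 to compound 2 (0.03 log units; within the scatter), so among these three compounds on the same sugar, only the shortened chain separates from the others, toward lower toxicity in this test.

From the compounds shown here alone, the full size of both new steps remains open, and so does the chain length at which the number starts to rise. Also unresolved is how an amine or a carboxylic acid in place of butyl would compare with hydrogen.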